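From 2-hydroxyphenyl to 3-carbamoylphenyl: a small step expected

The source may hold more compounds than are shown below. What is called first, only, known or untested is meant among the compounds shown, and "the series" means these compounds.

In an ADME assay (liver) for metabolic stability, with Liver microsome (Rattus norvegicus) as the target, using microsomes and NADPH, with a stated time of 30 min, tested at 1 uM (on this read-out higher numbers stand for fast clearance and lower numbers for slow clearance), compound 2 (`Nc1ccc(S(=O)(=O)N2CCN(c3ncc(C(O)(C(F)(F)F)C(F)(F)F)cc3-c3ccccc3O)CC2)cn1`) gives 125 mL.min-1.g-1. Compound 1 (`Nc1ccc(S(=O)(=O)N2CCN(c3ncc(C(O)(C(F)(F)F)C(F)(F)F)cc3C#CCO)CC2)cn1`) gives 65 mL.min-1.g-1, and the two numbers lie within the scatter of each other. Compound 3 (`NC(=O)c1cccc(-c2cc(C(O)(C(F)(F)F)C(F)(F)F)cnc2N2CCN(S(=O)(=O)c3ccc(N)nc3)CC2)c1`) has not yet been measured. It carries 3-carbamoylphenyl in place of 2-hydroxyphenyl on an aromatic carbon, and the count of that change reads: 3-carbamoylphenyl in place of 2-hydroxyphenyl on an aromatic carbon. Among the measured compounds shown here, only one measured step concerns this same place, where 2-hydroxyphenyl took the place of 3-hydroxyprop-1-yn-1-yl: a 1.9-fold higher number from compound 1 to compound 2 (0.28 log units; within the scatter). For the measured compounds named here, with that single step within the scatter as the only guide, no shift beyond the scatter is expected in this assay, and the data favour no clear direction. The expected change is a 1.1-fold lower number from compound 2 to compound 3 (0.06 log units; within the scatter). For compound 3 the estimated value is 110 mL.min-1.g-1, with an expected range of 50 mL.min-1.g-1 to 230 mL.min-1.g-1.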

Compound 3, intrinsic clearance in microsomes: 63 mL.min-1.g-1
Estimate against measurement, compound 3: 1.7-fold (0.24 log units) above, within the range that was stated.
By their numbers in this assay, from the lowest: compounds 3, 1 and 2 (each within the scatter of the next).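

In this assay the step of a 2.0-fold lower number from compound 2 to compound 3 (0.30 log units; within the scatter) comes with the exchange of 2-hydroxyphenyl for 3-carbamoylphenyl, and the step of a 1.0-fold lower number from compound 1 to compound 3 (0.01 log units; within the scatter) comes with the exchange of 3-hydroxyprop-1-yn-1-yl for 3-carbamoylphenyl. Among the compounds shown here, this place, on an aromatic carbon ortho to a large group, has now held three different groups, including one of 9 heavy atoms where 2-hydroxyphenyl has 7, and no step among them goes beyond the scatter. No measurement at hand bears on why the numbers fall as they do.

Going by these compounds, whether an amine or a carboxylic acid on the aromatic ring at this place, or a longer chain in place of 3-hydroxyprop-1-yn-1-yl, would bring a shift beyond the scatter remains open. So does the question of where a plain phenyl group would stand among these three compounds.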